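The source may hold more compounds than are shown below. What is called first, only, known or untested is meant among the compounds shown, and "the series" means these compounds.

Measured growth inhibition in a functional assay on DU-145 cells (Homo sapiens) for inhibition, read by trypan blue exclusion, with a stated time of 96 h (a higher number here means a weaker inhibitor of growth, a lower number a stronger inhibitor of growth), for three compounds
Compound 1 `COc1cc(/C=C(/SCc2ccc(Br)cc2)C(=O)c2ccc(C(=O)O)cc2)ccc1F` gives 1000 nM
Compound 2 `O=C(/C(=C\c1ccc(Br)c(O)c1)S(=O)(=O)c1ccc(Br)cc1)c1ccc(Br)cc1` gives 50000 nM
Compound 3 `Cc1ccc(S/C(=C/c2c[nH]c3ccc(Br)cc23)C(=O)c2ccc(Br)cc2)cc1` gives 1000 nM

Compound 1 stands level with compound 3 at the low end of these numbers, which marks the better growth inhibition here. Compound 2 lies far higher than compound 1 and is a much weaker inhibitor.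

Compound 4 `O=C(O)c1ccc(C(=O)/C(=C\c2ccc(Br)c([N+](=O)[O-])c2)SCc2ccc(Br)cc2)cc1` changes one group of compound 1 4-bromo-3-nitrophenyl in place of 4-fluoro-3-methoxyphenyl on a double-bonded chain carbon bound to a double-bonded chain carbon with 4-bromo-3-nitrophenyl in place of 4-fluoro-3-methoxyphenyl on a double-bonded chain carbon bound to a double-bonded chain carbon. Among the measured compounds shown here, no measured pair isolates a single change, so these data cannot size this swap directly. In this assay a modest shift toward a higher number is expected, perhaps none beyond the scatter. The expected change is a 1.5-fold higher number from compound 1 to compound 4 (0.18 log units; within the scatter) and remains an estimate. For compound 4 the estimated value is 1500 nM with 300 nM to 8000 nM as the expected range.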

Compound 4, concentration for 50% growth inhibition: 1000 nM
The estimate for compound 4 lay 1.5-fold (0.18 log units) above the measured number; the measured number falls inside the stated range.
By their numbers in this assay, from the lowest: compounds 1, 3 and 4 (each within the scatter of the next); then compound 2.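

In this assay, among the compounds shown here, placing 4-bromo-3-nitrophenyl in place of 4-fluoro-3-methoxyphenyl gives no change at the digits printed from compound 1 to compound 4 (within the scatter) and is the only single-place comparison in this set. On a double-bonded chain carbon bound to a double-bonded chain carbon, these two differently substituted rings therefore cannot be told apart by growth inhibition. Nothing measured here gives a reason for this.

On these data alone, the swap replaces both ring substituents at once, so the separate contribution of each remains unknown. As far as these compounds go, how an unsubstituted phenyl or an amine-bearing phenyl would compare also remains open.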